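The source may report more compounds than this note shows. Statements on the series, on what has been measured and on what is new or still open speak of the compounds shown alone.

In an assay on cell membranes (strain Wistar) for inhibition of Fatty-acid amide hydrolase 1 (Rattus norvegicus), read by scintillation counting (a higher number here means a weaker inhibitor, a lower number a stronger inhibitor), compound 1 `CCCCNC(=O)Oc1ccc(C2=NCCO2)cc1` gives 120 nM and compound 2 `O=C(NC1CCCC1)Oc1ccc(C2=NCCO2)cc1` gives 100 nM; the step of a 1.2-fold lower number from compound 1 to compound 2 (0.08 log units; within the scatter) stays within the scatter. Compound 2 stands at the lower of the two numbers, the gap to compound 1 being within the scatter. Compound 3 `O=C(NC1CCCC1)Oc1ccc(-c2csnn2)cc1` carries a group of 5 heavy atoms (2 carbon, 2 nitrogen, 1 sulfur; one five-membered aromatic ring with 3 hetero atoms) in place of a group of 5 heavy atoms (3 carbon, 1 nitrogen, 1 oxygen; one five-membered non-aromatic ring with 2 hetero atoms), on an aromatic carbon. Among the compounds with values here, the one measured step, from compound 1 to compound 2, alters the amide-type nitrogen side and bears little on this exchange at the ring; the change is untested here. The step of a 1.5-fold higher number from compound 2 to compound 3 (0.18 log units; within the scatter) is therefore only an expectation, with a wide range. Compound 3 is expected to give 150 nM, estimated between 40 nM and 600 nM.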

Compound 3, half-maximal inhibitory concentration: 20 nM
The estimate for compound 3 lay 7.5-fold (0.88 log units) above the measured number; the whole stated range lies above it.
By their numbers in this assay, from the lowest: compound 3; then compounds 2 and 1 (each within the scatter of the next).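

On an aromatic carbon of a six-membered aromatic ring of carbon only, 1,2,3-thiadiazol-4-yl in place of the five-membered non-aromatic ring gives a 5.0-fold lower number from compound 2 to compound 3 (0.70 log units; beyond the scatter) in this assay. Within the data shown here, this is the first change to move the number beyond the scatter, and it shows that this position matters more than the amide-type nitrogen side, where cyclopentyl and butyl stay within the scatter of each other. Still open, going by these compounds, is whether a phenyl or a 1,2,3-triazol-4-yl at this position would give a similar number, and whether the gain holds with butyl on the nitrogen. No supporting data bear on the origin of this step.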